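This account rests on a few compounds, and the source may have more. Where it says the series, first, only, none or still open, it means among the compounds named here.

In a functional assay on HeLa cells (Homo sapiens) for cytotoxicity, read by MTT assay, with a stated time of 72 h (a higher number here means a weaker inhibitor, a lower number a stronger inhibitor), compound 1 `O=c1c(CSc2cc(=O)c3ccccc3s2)coc2ccccc12` gives 2600 nM. Compound 2 `Cc1nnc(SCc2cc(=O)c3ccccc3o2)s1` reaches only the limit of this assay, reported as > 25000 nM. Compound 2 thus stands at the limit of > 25000 nM in this assay, at which 1 of the 2 values shown sits, a limit rather than a number. Compound 3 `Nc1nnc(SCc2cc(=O)c3ccccc3o2)s1` differs from compound 2 by amino in place of methyl on an aromatic carbon. Among the compounds with values here, no measured step covers this change, so no shift beyond the scatter is expected in this assay, and the limit is expected to remain. The expected step is a step that the limit leaves unreadable from compound 2 to compound 3. Compound 3 is estimated at 30000 nM, within 8000 nM to 100000 nM.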

Compound 3, half-maximal inhibitory concentration: > 25000 nM
Compound 3: a limit, no number; the forecaster's own chance of this, stated with the estimate: 70%; the middle value does not contradict the limit.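

In this assay, within the data shown here, compound 2 and compound 3 both stand at a limit rather than a number, so no step between them can be read. The compounds shown leave open whether amino in place of methyl on an aromatic carbon shifts the read-out in this assay at all.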